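Sulfonamide Chain Extension on a Shared Core

The source may hold more compounds than are shown below. What is called first, only, known or untested is meant among the compounds shown, and "the series" means these compounds.

Measured compounds:
Compound 1 `CS(=O)(=O)N[C@@H](CNC(=O)c1ccc2c(c1)C(=O)N(CCC1CCNCC1)C2)C(=O)O`: 14 nM
Compound 2 `CCCCS(=O)(=O)N[C@@H](CNC(=O)c1ccc2c(c1)C(=O)N(CCC1CCNCC1)C2)C(=O)O`: 14 nM; 9 nM (2 entries)

In a functional assay for inhibition, with Homo sapiens as the target (on this read-out lower numbers stand for stronger inhibition and higher numbers for weaker inhibition), compound 1 gives 14 nM, the only number shown for it. Compound 2, which carries a longer chain on the sulfonyl group, gives 14 nM; 9 nM (2 entries); these values show no difference beyond the usual scatter, as seen in the several entries of compound 2 in this assay, 14 nM; 9 nM (2 entries). Compound 3 `CCOCCS(=O)(=O)N[C@@H](CNC(=O)c1ccc2c(c1)C(=O)N(CCC1CCNCC1)C2)C(=O)O` has not been measured. It differs from compound 1 by ethoxymethyl in place of hydrogen on a saturated chain carbon bound to a sulfonyl sulfur. Since lengthening the sulfonyl chain left the read-out unchanged, a step of about no size beyond the scatter is expected: a 1.2-fold lower number from compound 1 to compound 3 (0.07 log units; within the scatter). Compound 3 is therefore expected to give 12 nM, with a likely range from 5 nM to 30 nM.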

Compound 3, half-maximal inhibitory concentration: 8 nM
The estimate for compound 3 lay 1.5-fold (0.18 log units) above the measured number; measured number inside the range.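

In this assay the change from methyl to 2-ethoxyethyl on the sulfonyl group gives a 1.8-fold lower number from compound 1 to compound 3 (0.24 log units; within the scatter) and so adds a second longer chain that leaves the read-out within the scatter. This position therefore accepts a chain containing oxygen as well as the all-carbon chain of compound 2. How far repeat readings can differ is shown here: the several entries of compound 2 in this assay, 14 nM; 9 nM (2 entries).

Still open, going by these compounds, is whether an amine, a carboxylic acid or a phenyl ring at the end of this chain would keep the read-out at this level.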